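Extending the sulfonamide of compound 2

A few compounds are considered here, and "the series" means these few. Any claim that something is new, unique, unknown or untested is made for them only; others in the source may bear on it.

In a functional assay on MDA-MB-231 cells (Homo sapiens) for inhibition, read by MTT assay, with a stated time of 48 h (on this read-out lower numbers stand for stronger inhibition of growth and higher numbers for weaker inhibition of growth), compound 1 (`Oc1ccc(Nc2ncnc3ccc(NC(=S)NCc4ccccc4)cc23)cc1`) gives 27000 nM. Compound 2 (`NS(=O)(=O)c1ccc(Nc2ncnc3ccc(NC(=S)NCc4ccccc4)cc23)cc1`) stands at > 30000 nM, which is a limit of the assay and not a number. Its place on the numbers shown is thus (the limit of > 30000 nM in this assay, at which 1 of the 2 values shown sits).

Compound 3 (`N=C(N)NS(=O)(=O)c1ccc(Nc2ncnc3ccc(NC(=S)NCc4ccccc4)cc23)cc1`) keeps the shared core and the sulfonamide of compound 2 and differs only in one substitution: a group of 3 heavy atoms (1 carbon, 2 nitrogen; no ring) in place of a hydrogen atom, on a sulfonamide nitrogen. Going by the values given here, one measured step bears on this change, an at least 1.1-fold higher number from compound 1 to compound 2 (0.04 log units; that floor lies within the scatter). That step exchanges the group on an aromatic carbon which compound 3 carries further, and it does not touch the sulfonamide nitrogen itself, so it is only indirect support. With that single step as the guide, no step beyond the scatter is expected in this assay, and neither direction is favoured. The estimated step is an at least 1.0-fold lower number from compound 2 to compound 3 (0.02 log units; that floor lies within the scatter). A report of compound 3 only as a limit would be no surprise. For compound 3 the expected value is 28000 nM, with an estimated range of 12000 nM to 65000 nM.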

Compound 3, concentration for 50% growth inhibition: > 30000 nM
Compound 3 ended at the assay's limit; the forecaster's own chance of this, stated with the estimate: 50%; at least 1.0-fold (0.02 log units) between middle value and limit.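

In this assay, compound 3 joins compound 2 at a limit of the assay and not at a number: the limit of > 30000 nM in this assay, at which 2 of the 3 values shown sit.

The step between these two compounds cannot be read, so the new group on the sulfonamide nitrogen shows neither a gain nor a loss; what is new is only that this substitution does not bring the series to a number in this assay. Going by these compounds alone, the one readable step is an at least 1.1-fold higher number from compound 1 to compound 3 (0.04 log units; that floor lies within the scatter); as a floor within the scatter, it sets no order among the compounds.

On these data alone, the actual values of compound 2 and compound 3 remain unknown, so any difference between them stays hidden. Also open, as far as these compounds go, is whether a methyl group or a longer chain on the sulfonamide nitrogen, or a carboxylic acid in place of the sulfamoyl group on the aromatic carbon, would give a number rather than a limit.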